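Swapping the pendant aryl ring: from fluorophenyl to dimethylphenyl

This account rests on a few compounds, and the source may have more. Where it says the series, first, only, none or still open, it means among the compounds named here.

This series shares one core and differs only in the aryl group attached to it. Compound 1 `Cc1cc(-c2cccc(C#N)c2)cc(C)c1Nc1ccnc(Nc2ccc(C#N)cc2)n1` gives 920 nM in an ADME assay on MT4 cells (Homo sapiens) for cytotoxicity, read by MTT assay, with a stated time of 4 days; on this read-out higher numbers stand for lower toxicity in this test and lower numbers for higher toxicity in this test. Compound 2 `Cc1cc(-c2ccc(C(F)(F)F)cc2)cc(C)c1Nc1ccnc(Nc2ccc(C#N)cc2)n1` gives 4160 nM in this assay, and compound 3 `Cc1cc(-c2ccccc2F)cc(C)c1Nc1ccnc(Nc2ccc(C#N)cc2)n1` gives 2120 nM. Among the three numbers compound 3 stands second highest: the step of a 2.3-fold higher number from compound 1 to compound 3 (0.36 log units; beyond the scatter) is modest, while the step of a 2.0-fold lower number from compound 2 to compound 3 (0.29 log units; within the scatter) stays within the scatter. Compound 4 `Cc1cc(-c2c(C)cccc2C)cc(C)c1Nc1ccnc(Nc2ccc(C#N)cc2)n1` is not yet measured; it differs from compound 3 by 2,6-dimethylphenyl in place of 2-fluorophenyl on an aromatic carbon. The two steps that bear on this change, a 2.3-fold higher number from compound 1 to compound 3 (0.36 log units; beyond the scatter) and a 2.0-fold lower number from compound 2 to compound 3 (0.29 log units; within the scatter), both alter the same aryl group and both move the number only a little, so the expected step of a 1.2-fold higher number from compound 3 to compound 4 (0.07 log units; within the scatter) from compound 3 to compound 4 is small and may not exceed the scatter. Compound 4 is therefore estimated at 2500 nM in this assay, with a likely range from 1000 nM to 6500 nM.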

Compound 4, half-maximal cytotoxic concentration: 2590 nM
Compound 4: the middle estimate sits 1.0-fold (0.02 log units) below what was measured; the measured number falls inside the stated range.
By their numbers in this assay, from the lowest: compound 1; then compounds 3, 4 and 2 (each within the scatter of the next).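

In this assay, 2,6-dimethylphenyl cannot be told apart from 2-fluorophenyl or 4-(trifluoromethyl)phenyl at this position: both a 1.2-fold higher number from compound 3 to compound 4 (0.09 log units; within the scatter) and a 1.6-fold lower number from compound 2 to compound 4 (0.21 log units; within the scatter) stay within the scatter. Only a 2.8-fold higher number from compound 1 to compound 4 (0.45 log units; beyond the scatter) goes beyond it, so a third aryl group now joins the other two, and 3-cyanophenyl remains the only one of the four that stands apart, with the lowest number. Nothing available explains why these groups fall together or why 3-cyanophenyl differs.

Within the data shown here, with only one compound carrying the lower number, it remains open whether the nitrile itself or its place on the ring goes with that result. Also open, on these data alone, is how this read-out responds to a ring carrying an amine or a carboxylic acid, or to a longer chain in place of the ring.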